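The source may hold more compounds than are shown below. What is called first, only, known or untested is meant among the compounds shown, and "the series" means these compounds.

For the measured compounds named here, in a functional assay on HepG2 cells (Homo sapiens) for cytotoxicity, read by MTT assay, with a stated time of 24 h (a higher number here means a weaker inhibitor, a lower number a stronger inhibitor), compound 2 (`CN1C/C(=C\c2ccc(C#N)cc2)C(=O)/C(=C/c2ccccc2F)C1`) gives 590 nM, the lower of the two numbers so far, while compound 1 (`COc1ccc(/C=C2\CN(C)C/C(=C\c3ccccc3F)C2=O)cc1`) gives 12300 nM. Compound 3 (`CN1C/C(=C\c2ccc(Br)cc2)C(=O)/C(=C/c2ccc(C#N)cc2)C1`) has 4-bromophenyl in place of 2-fluorophenyl on a double-bonded chain carbon bound to a double-bonded ring carbon. Going by the values given here, the only measured step, a 21-fold lower number from compound 1 to compound 2 (1.32 log units; beyond the scatter), is large, but it swapped methoxy for cyano at a different place, so it gives no direct size for this change. No shift beyond the scatter is therefore expected in this assay, although the uncertainty is wide. The estimated step is a 1.4-fold higher number from compound 2 to compound 3 (0.13 log units; within the scatter). For compound 3 the expected value is 800 nM, with an estimated range of 200 nM to 3500 nM.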

Compound 3, half-maximal inhibitory concentration: 4840 nM
Compound 3: middle estimate off by 6.1-fold (0.78 log units), on the low side, and the stated range ends below it.
By their numbers in this assay, from the lowest: compound 2; then compound 3; then compound 1.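

In this assay this place is sensitive to the aryl group it carries, as an 8.2-fold higher number from compound 2 to compound 3 (0.91 log units; beyond the scatter) shows for 4-bromophenyl in place of 2-fluorophenyl on a double-bonded chain carbon bound to a double-bonded ring carbon. For the compounds shown here, this is the first measured size for a change at this place, since the earlier step lay elsewhere. No evidence on hand accounts for the shift.

This step changes the halogen and its placement together, and the two cannot be separated here. As far as these compounds go, how an amine or a carboxylic acid on this aromatic ring would read remains open.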